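Capping the chain amine: from compound 2 to compound 4

The source may report more compounds than this note shows. Statements on the series, on what has been measured and on what is new or still open speak of the compounds shown alone.

Measured compounds:
compound 1, `CC(C)(C)OC(=O)NCCCNC(=O)CN1CN(c2ccccc2)C2(CCN(C(=O)c3ccc(C4CCCCC4)cc3)CC2)C1=O`, 6000 nM
compound 2, `CC(C)(C)c1ccc(C(=O)N2CCC3(CC2)C(=O)N(CC(=O)NCCN)CN3c2ccccc2)cc1`, 7000 nM
compound 3, `CC(C)(C)OC(=O)N1CCN(C(=O)CN2CN(c3ccccc3)C3(CCN(C(=O)c4ccc(C5CCCCC5)cc4)CC3)C2=O)CC1`, 3500 nM

The three measured compounds share one core and differ in the side chain that hangs from the amide carbonyl. In an assay on HEK293 cells for displacement of a labelled ligand from NPC1-like intracellular cholesterol transporter 1 (Homo sapiens) (on this read-out lower numbers stand for stronger inhibition and higher numbers for weaker inhibition), compound 2 gives 7000 nM, the highest of the three numbers; yet its gap to compound 1 and its gap to compound 3 both lie within the usual scatter, so the three compounds cannot be ranked against each other on these data.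

Compound 4, `CC(C)(C)c1ccc(C(=O)N2CCC3(CC2)C(=O)N(CC(=O)NCCCNS(C)(=O)=O)CN3c2ccccc2)cc1`, is not yet measured. It differs from compound 2 in one place: (methanesulfonamido)methyl in place of amino on a saturated chain carbon, two bonds along the chain from an amide-type nitrogen. Among the measured compounds shown here, no step between two measured compounds is available to calibrate this exact change. The nearest point of comparison is compound 1, whose chain also ends in a capped nitrogen rather than a free amine and which gives 6000 nM, a number within the scatter of compound 2.

On that basis the step from compound 2 to compound 4 is expected to be small, a 1.4-fold lower number from compound 2 to compound 4 (0.15 log units; within the scatter), and not clearly beyond the scatter in either direction. Compound 4 is therefore estimated at 5000 nM, with a range from 2000 nM to 14000 nM.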

Compound 4, half-maximal inhibitory concentration: 10400 nM
Beside the measured number, compound 4's estimate is 2.1-fold (0.32 log units) below it, within the range that was stated.
By their numbers in this assay, from the lowest: compounds 3, 1, 2 and 4 (each within the scatter of the next, the first and the last beyond it).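

In this assay, among the compounds shown here, the change read as 2-aminoethyl to 3-(methanesulfonamido)propyl gives a 1.5-fold higher number from compound 2 to compound 4 (0.17 log units; within the scatter) and is the only step read at this position of the shared core. The earlier compounds shown here could not show this, since no two of them differed in one place; now a single change at this chain end can be followed, and it replaces the free amine of compound 2 with a capped nitrogen and a group of six heavy atoms without moving the number beyond what repeated measurements would scatter. Nothing in the data shown accounts for this outcome or says how the amino and methanesulfonamido ends compare in any other respect.

The step also joins two differences, a longer chain and a capped nitrogen, so the compounds shown leave open which of them contributes what, a question that 3-aminopropyl or 2-(methanesulfonamido)ethyl at this place would separate. They also leave open how other chain ends, such as an acetamido group or a carboxylic acid, would read at this position.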